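Swapping the aminophenyl ketone for a difluorophenyl ketone

This account rests on a few compounds, and the source may have more. Where it says the series, first, only, none or still open, it means among the compounds named here.

Compound 1 `COc1cc(-c2cc(/C=C/C(=O)c3ccc(N)cc3)[nH]n2)cc(OC)c1OC` and compound 2 `COc1ccc(-c2cc(/C=C/C(=O)c3ccc(N)cc3)[nH]n2)cc1OC` share a core and differ only in that compound 2 carries hydrogen in place of methoxy on an aromatic carbon. Among the measured compounds shown here, in a functional assay on OVCAR-3 cells (Homo sapiens) for cytotoxicity, read by sulforhodamine B assay, with a stated time of 48 h, tested at 100 uM (a lower number here means a stronger effect, a higher number a weaker effect of the compound at the concentration tested), compound 1 gives -93%, and compound 2 gives -99%; the step of a number 6 percentage points lower from compound 1 to compound 2 (within the scatter) tells that the two values cannot be told apart, so compound 1 stands level with its only neighbour.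

Compound 3 `COc1cc(-c2cc(/C=C/C(=O)c3ccc(F)c(F)c3)[nH]n2)cc(OC)c1OC` differs from compound 1 as follows: 3,4-difluorophenyl in place of 4-aminophenyl on a carbonyl carbon. For the measured compounds named here, no measured step touches this part of the molecule; the single step between compound 1 and compound 2 lies on the other aromatic ring and was within the scatter, so it gives no guide to the size or direction of the new change. The expectation for compound 3 therefore rests on compound 1 alone, with wide uncertainty, and the step of a number 18 percentage points higher from compound 1 to compound 3 (beyond the scatter) is estimated. Compound 3 is expected to give -75% in this assay, between -100% and -30%.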

Compound 3, a percentage reported as activity, at one concentration (the size of the read-out at that concentration, not a potency): -64%
For compound 3 the middle estimate is 11 percentage points below the measured one; low and high end bracket the measured number.
By their numbers in this assay, from the lowest: compounds 2 and 1 (each within the scatter of the next); then compound 3.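

In this assay, the group on the carbonyl carbon proves to matter: 3,4-difluorophenyl in place of 4-aminophenyl gives a number 29 percentage points higher from compound 1 to compound 3 (beyond the scatter), a weaker effect at the concentration tested, although compound 3 still reads -64%. The earlier change, hydrogen in place of methoxy on an aromatic carbon, gave a number 6 percentage points lower from compound 1 to compound 2 (within the scatter), which makes this the first single change shown that moves the read-out beyond the scatter. Nothing available explains the shift.

The swap removes the amine and brings in two fluorines in one step, and the compounds shown cannot separate these two parts of the change. Going by these compounds, it remains open whether an unsubstituted phenyl, a phenyl with a single fluorine or a hydroxyphenyl on the carbonyl carbon would read closer to compound 1 or to compound 3.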